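The compounds below may be only part of what the source reports. "The series", "measured", "known", "first", "only" and "open" are said of these compounds alone.

Compound 3 `COc1ccc(NC(=O)C(=O)c2cn(CC3CCO3)c3ccccc23)cn1` gives 686 nM in a functional assay on FaDu cells (Homo sapiens) for cytotoxicity, read by MTT assay, with a stated time of 72 h (a higher number here means that more compound is tolerated, a lower number that less compound is tolerated), the highest of the three numbers recorded; it sits well apart from compound 1 `COc1ccc(NC(=O)C(=O)c2cn(C(C)C)c3ccccc23)cn1`, which gives 85 nM, and further still from compound 2 `CCCCn1cc(C(=O)C(=O)Nc2ccc(OC)nc2)c2ccccc21`, which gives 18 nM. The unmeasured compound 4 `COc1ccc(NC(=O)C(=O)c2cn(C(C)(C)COCC(=O)O)c3ccccc23)cn1` differs from compound 3 at the same aromatic nitrogen that varies across the series: a group of 9 heavy atoms (6 carbon, 3 oxygen; no ring) in place of a group of 5 heavy atoms (4 carbon, 1 oxygen; one four-membered non-aromatic ring with 1 hetero atom), on an aromatic nitrogen. Going by the values given here, two measured steps touch this position. Replacing isopropyl with (oxetan-2-yl)methyl gave an 8.1-fold higher number from compound 1 to compound 3 (0.91 log units; beyond the scatter), and the change from propyl to oxetan-2-yl on the chain carbon gave a 38-fold higher number from compound 2 to compound 3 (1.58 log units; beyond the scatter); in both, a group carrying an oxygen in place of a plain alkyl group raised the number, while the step of a 4.7-fold lower number from compound 1 to compound 2 (0.67 log units; beyond the scatter) lowered it. Among the compounds with values here, with no direct precedent for a group of this size and with three oxygens at that nitrogen, the direction is read from those two steps, and a further rise is expected for compound 4, though its size is uncertain. Compound 4 is therefore estimated to give 2500 nM in this assay, within a range of 700 nM to 9000 nM. This estimate corresponds to an expected step of a 3.6-fold higher number from compound 3 to compound 4 (0.56 log units; beyond the scatter), beyond the scatter but not firmly so.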

Compound 4, concentration lethal to 50% of the cells: > 10000 nM
Compound 4 gave a limit, no number; the forecaster's own chance of this, stated with the estimate: 15%; middle value at least 4.0-fold (0.60 log units) from the limit.
By their numbers in this assay, from the lowest: compound 2; then compound 1; then compound 3. At a limit, above all of these: compound 4.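

In this assay compound 4 stands at a limit of the assay and not at a number: the limit of > 10000 nM in this assay, at which 1 of the 4 values shown sits. Going by these compounds alone, this widens what the position on the aromatic nitrogen was known to span, since the new group gives an at least 14-fold higher number from compound 3 to compound 4 (1.16 log units; beyond the scatter) and, against the plain butyl group, an at least 550-fold higher number from compound 2 to compound 4 (2.74 log units; beyond the scatter), both large steps that reach past anything the earlier compounds showed. The step from isopropyl is the most telling. It changes only one place: (carboxymethoxy)methyl in place of hydrogen on the saturated chain carbon, with that branched carbon kept, gives an at least 110-fold higher number from compound 1 to compound 4 (2.07 log units; beyond the scatter), so this addition alone is enough to carry the number to the limit, and the entering group is also the first here to hold a hydrogen-bond donor.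

Going by these compounds, how far compound 4 lies past the limit stays unknown, so the true size of all three steps remains open. Also open, on these data alone, is which part of the group counts, as it is not known whether a methyl ester of the same chain, an amine at its end, or a longer plain alkyl chain on that branched carbon would give the same result.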